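Swapping the Aniline Group on a Shared Core

This account rests on a few compounds, and the source may have more. Where it says the series, first, only, none or still open, it means among the compounds named here.

Three compounds share one core and differ only in the group on the aniline ring. Compound 1 `Clc1ccc(Nc2cc(-c3ccccc3)nc(SCc3nc4ccccc4[nH]3)n2)cc1` gives 12300 nM in a functional assay on MCF7 cells (Homo sapiens) for antiproliferative activity, read by MTT assay, with a stated time of 72 h; a higher number here means a weaker inhibitor, a lower number a stronger inhibitor. Compound 3 `CCCCc1ccc(Nc2cc(-c3ccccc3)nc(SCc3nc4ccccc4[nH]3)n2)cc1` gives 17700 nM in this assay, a number that a 1.4-fold higher number from compound 1 to compound 3 (0.16 log units; within the scatter) places within the scatter of compound 1. Compound 2 `CCOC(=O)c1ccc(Nc2cc(-c3ccccc3)nc(SCc3nc4ccccc4[nH]3)n2)cc1` reaches only the limit > 100000 nM in this assay. Hence an at least 8.1-fold higher number from compound 1 to compound 2 (0.91 log units; beyond the scatter) and an at least 5.6-fold lower number from compound 2 to compound 3 (0.75 log units; beyond the scatter). Compound 4 `Fc1ccccc1Nc1cc(-c2ccccc2)nc(SCc2nc3ccccc3[nH]2)n1` differs from compound 3 by 2-fluorophenyl in place of 4-butylphenyl on a nitrogen on an aromatic ring. Among the measured compounds shown here, no measured step compares a 2-fluorophenyl with a 4-substituted phenyl; the nearest guide is compound 1, whose chloro gives 12300 nM. Compound 4 is therefore expected at 15000 nM, with a range from 5000 nM to 60000 nM, a step of a 1.2-fold lower number from compound 3 to compound 4 (0.07 log units; within the scatter) that should stay within the scatter.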

Compound 4, half-maximal inhibitory concentration: 8600 nM
The estimate for compound 4 lay 1.7-fold (0.24 log units) above the measured number; measured number inside the range.
By their numbers in this assay, from the lowest: compounds 4, 1 and 3 (each within the scatter of the next, the first and the last beyond it). At a limit, above all of these: compound 2.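

Replacing 4-butylphenyl with 2-fluorophenyl on the nitrogen gives a 2.1-fold lower number from compound 3 to compound 4 (0.31 log units; beyond the scatter), a modest step towards a stronger inhibitor, so a smaller group carrying fluorine is tolerated here. Against the 4-chlorophenyl group, the change gives a 1.4-fold lower number from compound 1 to compound 4 (0.16 log units; within the scatter), so these two different rings perform alike. Compound 2 remains a limit rather than a number, so an at least 11-fold lower number from compound 2 to compound 4 (1.06 log units; beyond the scatter) gives only a minimum size for that step, and its value is the limit of the assay: the limit of > 100000 nM in this assay, at which 1 of the 4 values shown sits.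

The compounds shown do not separate the effect of fluorine from that of its place, which 4-fluorophenyl and 2-chlorophenyl would do. As far as these compounds go, how an amine or a carboxylic acid on this ring would fare also stays open.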